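Replacing tert-butyl with propoxy on a trans stilbene

The source may report more compounds than this note shows. Statements on the series, on what has been measured and on what is new or still open speak of the compounds shown alone.

Measured compounds:
Compound 1, `COc1cc(/C=C/c2ccc(C(C)(C)C)cc2)cc(OC)c1OC`, > 25 uM
Compound 2, `COc1cc(/C=C\c2ccc(C(C)(C)C)cc2)cc(OC)c1OC`, 1.02 uM
Compound 3, `COc1ccc(C(O)c2cc(OC)c(OC)c(OC)c2)cc1`, 1.5 uM

In a functional assay on A549 cells (Homo sapiens) for cytotoxicity (on this read-out higher numbers stand for an effect only at larger amounts of compound and lower numbers for an effect already at smaller amounts), compound 1 gives only a limit, > 25 uM, at which (the limit of > 25 uM in this assay, at which 1 of the 3 values shown sits). Compound 2 gives 1.02 uM in this assay, and compound 3 gives 1.5 uM. Among the compounds with values here, the one measured step, an at least 24-fold lower number from compound 1 to compound 2 (1.38 log units; beyond the scatter), rests on the fact that compounds 1 and 2 differ only in the configuration as drawn and changes nothing in the substituents.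

Compound 4, `CCCOc1ccc(/C=C/c2cc(OC)c(OC)c(OC)c2)cc1`, differs from compound 1 in one place: propoxy in place of tert-butyl on an aromatic carbon. Within the data shown here, no measured step covers an exchange of one group for another on that ring, so the configuration step from compound 1 to compound 2 does not speak to it, and compound 3 shares the trimethoxy ring but not the stilbene double bond. With nothing to point the other way, the estimate for compound 4 is a step of a number no higher from compound 1 to compound 4 (the limit leaves the size open) in this assay, that is, no change beyond the scatter. Compound 4 is therefore expected to give about 25 uM in this assay, within 6 uM to 60 uM, and most likely again only a limit.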

Compound 4, concentration for half-maximal effect: 9.2 uM
Compound 4: the middle estimate sits 2.7-fold (0.43 log units) above what was measured; measured number inside the range.
By their numbers in this assay, from the lowest: compounds 2 and 3 (each within the scatter of the next); then compound 4. At a limit, above all of these: compound 1.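

In this assay, the exchange of tert-butyl for propoxy on an aromatic carbon gives an at least 2.7-fold lower number from compound 1 to compound 4 (0.43 log units; beyond the scatter), so this position responds to a change of group, which the configuration step alone could not show. Compound 4 keeps the double bond drawn E and still gives a measured number, so that configuration does not by itself hold a compound at the limit. The full size of the step stays unknown because the value of compound 1 is only a limit: the limit of > 25 uM in this assay, at which 1 of the 4 values shown sits.

The compounds shown leave open whether the entering oxygen or the chain on it carries the step, and a plain propyl group, butoxy or an amine at this place would speak to that. They also leave open what propoxy does on the Z double bond of compound 2.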